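Cyclohexyl in place of methylamino on compound 2

A few compounds are considered here, and "the series" means these few. Any claim that something is new, unique, unknown or untested is made for them only; others in the source may bear on it.

In a functional assay on cells (Homo sapiens), read by thymidine incorporation (on this read-out higher numbers stand for weaker inhibition and lower numbers for stronger inhibition), compound 1 (`Cc1cc(NCc2cccnc2)n2ncc(Br)c2n1`) gives 1800 nM and compound 2 (`CNc1cc(NCc2cccnc2)n2ncc(Br)c2n1`) gives 1200 nM. Among the measured compounds shown here, the two cannot be separated: the only measured step, a 1.5-fold lower number from compound 1 to compound 2 (0.18 log units; within the scatter), is methylamino in place of methyl on an aromatic carbon. Compound 2 therefore stands level with compound 1. Compound 3 (`Clc1ccccc1-c1cc(NCc2cccnc2)n2ncc(Br)c2n1`), which has a ring-bearing group in place of methylamino on that carbon, gives 500 nM; 500 nM (2 entries), a lower number than compound 2 at 1200 nM.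

Compound 4 (`Brc1cnn2c(NCc3cccnc3)cc(C3CCCCC3)nc12`) has cyclohexyl in place of methylamino on an aromatic carbon. The measured step says little about a change of this size, and no saturated ring has been measured here. Only the value of compound 3 points in a direction, so a modest move towards a lower number is expected. The expected step is a 2.2-fold lower number from compound 2 to compound 4 (0.34 log units; beyond the scatter). For compound 4 the estimated value is 550 nM, with an expected range of 180 nM to 1700 nM.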

Compound 4, half-maximal inhibitory concentration: 200 nM
Compound 4: the middle estimate sits 2.8-fold (0.44 log units) above what was measured; the measured number falls inside the stated range.
By their numbers in this assay, from the lowest: compound 4; then compounds 2 and 1 (each within the scatter of the next).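

In this assay, this aromatic carbon proved responsive to the group it carries, which the methyl and methylamino pair could not show: cyclohexyl in place of methylamino gives a 6.0-fold lower number from compound 2 to compound 4 (0.78 log units; beyond the scatter), and cyclohexyl in place of methyl gives a 9.0-fold lower number from compound 1 to compound 4 (0.95 log units; beyond the scatter). A ring on this carbon need not be aromatic, nor carry a hydrogen-bond donor or acceptor, to reach this range: compound 3 gives 500 nM; 500 nM (2 entries) and compound 4 gives 200 nM. Nothing available explains why the cyclohexyl compound gives the lower numbers.

Open, on these data alone, is whether the ring itself matters or the number of carbons alone, which cyclopentyl, cycloheptyl or an open hexyl chain would separate. Also open, as far as these compounds go, is how a ring nitrogen or oxygen would fare here, as in piperidine or morpholine.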